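The compounds below may be only part of what the source reports. "The series", "measured", "known", "first", "only" and "open" are said of these compounds alone.

Of the compounds shown here, three built on a shared core have been tested in a functional assay on B16 cells (Mus musculus) for antiproliferative activity, read by MTT assay, with a stated time of 48 h; on this read-out higher numbers stand for weaker inhibition and lower numbers for stronger inhibition. Compound 1, `CC1(C)Cc2c(ccc(C(=O)/C=C/c3cn(-c4ccccc4)nc3-c3cccc([N+](=O)[O-])c3)c2OCc2ccccc2)O1`, gives > 50000 nM in this assay, a reading that is a limit of the assay rather than a number. Compound 2, `CC1(C)Cc2c(OCc3ccccc3)ccc(C(=O)/C=C/c3cn(-c4ccccc4)nc3-c3ccc([N+](=O)[O-])cc3)c2O1`, gives > 100000 nM in this assay, again a limit and not a measured value. Compound 3, `CC1(C)Cc2c(ccc(C(=O)/C=C/c3ccccc3)c2OCc2ccccc2)O1`, gives > 100000 nM in this assay, which is also a limit. Compound 3 thus sits at the limit of > 100000 nM in this assay, at which 2 of the 3 values shown sit. Among the compounds with values here, the one remaining reading rests at the limit of > 50000 nM in this assay, at which 1 of the 3 values shown sits. Since none of the three readings is a real number, no ordering among these compounds can be drawn from them.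

Compound 4, `CC1(C)Cc2c(ccc(C(=O)/C=C/c3ccc(F)cc3)c2OCc2ccccc2)O1`, differs from compound 3 in one place: fluoro in place of hydrogen on an aromatic carbon. Within the data shown here, no measured step between compounds that differ in a single place is available here, so the size of such a step in this assay is not known from the data. A change of this kind is expected to shift the reading in this assay by no more than the usual scatter, in no particular direction; the expected step is a number no higher from compound 3 to compound 4 (the limit leaves the size open). Compound 4 is therefore estimated to read near 100000 nM, between 30000 nM and 300000 nM, and most probably as a limit once more rather than a number.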

Compound 4, half-maximal inhibitory concentration: > 100000 nM
Compound 4: no number, only a limit; the forecaster's own chance of this, stated with the estimate: 85%; the middle value sits exactly at the limit.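

Compound 3 and compound 4 each give only a limit of this assay and not a number, so the step between them cannot be read. The compounds shown leave open whether fluoro in place of hydrogen on an aromatic carbon changes the reading at all, and what change to the shared core would yield a real number.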